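The source may hold more compounds than are shown below. What is called first, only, known or untested is meant among the compounds shown, and "the series" means these compounds.

Working notes on the series built on the core of compound 1 (`Cn1c(C(F)(F)F)nc2cc(Cl)c(Cl)cc21`), read in a functional assay on MCF7 cells (Homo sapiens) for cytotoxicity, read by MTT assay, with a stated time of 48 h; a higher number here means a weaker inhibitor of growth, a lower number a stronger inhibitor of growth. Compound 1 gives 39000 nM, compound 2 (`C=CCn1c(C(F)(F)F)nc2cc(Cl)c(Cl)cc21`) gives 87000 nM, and compound 3 (`FC(F)(F)c1nc2cc(Cl)c(Cl)cc2n1Cc1ccccc1`) gives 8700 nM, the lowest number of the three.

The next step leads from compound 3 to compound 4 (`FC(F)(F)c1cccc(Cn2c(C(F)(F)F)nc3cc(Cl)c(Cl)cc32)c1`): trifluoromethyl in place of hydrogen on an aromatic carbon. This is trifluoromethyl in place of hydrogen on an aromatic carbon, meta to a large group.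

For the measured compounds named here, no measured step changes a substituent on that aromatic ring, so the evidence is indirect. The nearest steps change the group on the saturated chain carbon bound to the aromatic nitrogen. Phenyl in place of hydrogen gives a 4.5-fold lower number from compound 1 to compound 3 (0.65 log units; beyond the scatter), phenyl in place of vinyl gives a 10-fold lower number from compound 2 to compound 3 (1.00 log units; beyond the scatter), and vinyl in place of hydrogen gives a 2.2-fold higher number from compound 1 to compound 2 (0.35 log units; beyond the scatter). All three are modest, and the two phenyl steps both go to a lower number, while the vinyl step goes the other way.

On this limited basis, a modest step to a lower number is expected in this assay. The estimated step is a 2.2-fold lower number from compound 3 to compound 4 (0.34 log units; beyond the scatter). For compound 4 the estimated value is 4000 nM, with an expected range of 1500 nM to 11000 nM.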

Compound 4, concentration for 50% growth inhibition: 68000 nM
For compound 4 the middle estimate is 17-fold (1.23 log units) below the measured one, and the stated range ends below it.
By their numbers in this assay, from the lowest: compound 3; then compounds 1, 4 and 2 (each within the scatter of the next, the first and the last beyond it).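

In this assay, for the compounds shown here, trifluoromethyl in place of hydrogen on an aromatic carbon, meta to a large group, gives a 7.8-fold higher number from compound 3 to compound 4 (0.89 log units; beyond the scatter), the first reading of any substituent on this ring. The earlier steps shown here changed only the group on the saturated chain carbon bound to the aromatic nitrogen, and the two that introduced phenyl went to a lower number; this step shows that the lower number of compound 3 does not carry over to this substituted ring, so the ring position is sensitive to this change in a direction the chain steps could not reveal. No measurement in hand bears on why the number rises at this position.

The series shows a single substituent at a single ring position, so it leaves open whether a smaller group such as fluorine or methyl, or a methoxy group, an amine or a carboxylic acid, on the same aromatic carbon would also raise the number. It also leaves open whether trifluoromethyl on a different carbon of the ring would give a step of this direction and size.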